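This account rests on a few compounds, and the source may have more. Where it says the series, first, only, none or still open, it means among the compounds named here.

Measured compounds in an ADME assay on GES1 cells (Homo sapiens) for cytotoxicity, read by MTT assay, with a stated time of 24 h; a lower number here means that less compound is tolerated, a higher number that more compound is tolerated:
- compound 1 `O=c1[nH]cc(S(=O)(=O)Nc2ccc(-c3cn(-c4ccccc4)nn3)cc2)c(=O)[nH]1`: "not toxic" (no number reported)
- compound 2 `O=c1[nH]cc(S(=O)(=O)Nc2ccc(-c3cn(-c4cccc(F)c4)nn3)cc2)c(=O)[nH]1`: "not toxic" (no number reported)
- compound 3 `O=c1[nH]cc(S(=O)(=O)Nc2ccc(-c3cn(-c4ccccc4Cl)nn3)cc2)c(=O)[nH]1`: 16400 nM

Going by the values given here, compound 3 is the only member of the series with a reported number in this assay; compounds 1 and 2 carry a verbal result without a value, so no comparison of size can be drawn among the three. Compound 4 `O=c1[nH]cc(S(=O)(=O)Nc2ccc(-c3cn(-c4cccc(Cl)c4)nn3)cc2)c(=O)[nH]1` is not yet measured. It differs from compound 3 in one place: 3-chlorophenyl in place of 2-chlorophenyl on an aromatic nitrogen, in words 3-chlorophenyl in place of 2-chlorophenyl on an aromatic nitrogen. Among the compounds with values here, no measured pair in this set shows the effect of such a change. Within the data shown here, the two compounds have the same atoms, joined differently, and the series so far shows little spread. For compound 4 the expected result in this assay is 18000 nM, with a range from 7000 nM to 45000 nM. The step from compound 3 to compound 4 is expected to be a 1.1-fold higher number from compound 3 to compound 4 (0.04 log units; within the scatter), none beyond the scatter.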

Compound 4, half-maximal cytotoxic concentration: 7570 nM
The estimate for compound 4 lay 2.4-fold (0.38 log units) above the measured number; low and high end bracket the measured number.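

In this assay the position on the aromatic nitrogen proves sensitive to where the chlorine sits: 3-chlorophenyl in place of 2-chlorophenyl gives a 2.2-fold lower number from compound 3 to compound 4 (0.34 log units; beyond the scatter), so less compound is tolerated with the same atoms joined differently. Going by these compounds alone, this is the first numerical step, as the verbal results of compounds 1 and 2 allow no size comparison. No supporting data bear on why the number shifts. As far as these compounds go, whether an amine or a carboxylic acid in place of the chlorine would move the number remains open.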